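The source may hold more compounds than are shown below. What is called first, only, known or untested is meant among the compounds shown, and "the series" means these compounds.

Going by the values given here, in an ADME assay on Caco-2 cells (Homo sapiens) for permeability, read by LC-MS, in the apical to basolateral direction, with a stated time of 60 min, at pH 6.5 (on this read-out lower numbers stand for lower permeability and higher numbers for higher permeability), three compounds with a shared core have numbers so far: compound 1 `CC(C)(C)C[C@@H](O)C(=O)N1N=CC[C@H]1C(=O)NCc1cc(Cl)ccc1-n1cnnn1` gives 24 10^-6 cm/s, compound 2 `CC(C)CC[C@@H](O)C(=O)N1N=CC[C@H]1C(=O)NCc1cc(Cl)ccc1-n1cnnn1` gives 29 10^-6 cm/s, and compound 3 `COC(C)(C)[C@@H](O)C(=O)N1N=CC[C@H]1C(=O)NCc1cc(Cl)ccc1-n1cnnn1` gives 1.7 10^-6 cm/s, the lowest of the three. Compound 4 `O=C(NCc1cc(Cl)ccc1-n1cnnn1)[C@@H]1CC=NN1C(=O)[C@H](O)C1CCCCC1` has cyclohexyl in place of 1-methoxy-1-methylethyl on a saturated chain carbon bound to a carbonyl carbon and an oxygen on a saturated carbon. Among the compounds with values here, no measured compound carries this ring, so the evidence is indirect. The closest guides are a 14-fold lower number from compound 1 to compound 3 (1.15 log units; beyond the scatter) and a 17-fold lower number from compound 2 to compound 3 (1.23 log units; beyond the scatter), both large, which introduce the group that compound 4 gives up. In contrast, a 1.2-fold higher number from compound 1 to compound 2 (0.08 log units; within the scatter) lies within the scatter, showing no separation between the two groups made only of carbon. Cyclohexyl also holds only carbon, so a large upward move in this assay is expected, somewhat smaller than those two steps. The expected change is an 11-fold higher number from compound 3 to compound 4 (1.02 log units; beyond the scatter). For compound 4 the estimated value is 18 10^-6 cm/s, with an expected range from 6 10^-6 cm/s to 40 10^-6 cm/s.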

Compound 4, apparent permeability: 19 10^-6 cm/s
Beside the measured number, compound 4's estimate is 1.1-fold (0.02 log units) below it; measured number inside the range.
By their numbers in this assay, from the lowest: compound 3; then compounds 4, 1 and 2 (each within the scatter of the next).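

In this assay, the new result shows that a ring is accepted at this position, on a saturated chain carbon bound to a carbonyl carbon and an oxygen on a saturated carbon: cyclohexyl does not separate from the open carbon groups, with a 1.5-fold lower number from compound 2 to compound 4 (0.18 log units; within the scatter) and a 1.3-fold lower number from compound 1 to compound 4 (0.10 log units; within the scatter). Going by these compounds alone, the large step, an 11-fold higher number from compound 3 to compound 4 (1.05 log units; beyond the scatter), leaves compound 3 alone among the four, and its 1-methoxy-1-methylethyl is the only group at this position that holds oxygen. No measurement is at hand that explains this gap.

With a single oxygen-bearing group at this position, the low number cannot yet be assigned to the oxygen itself rather than to 1-methoxy-1-methylethyl as a whole. On these data alone, a methoxy group placed further out on a longer chain could separate these two readings, and how an amine at this position would behave remains open.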